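This account rests on a few compounds, and the source may have more. Where it says the series, first, only, none or still open, it means among the compounds named here.

Measured so far in a functional assay on B16-F10 cells (Mus musculus) for inhibition, tested at 5 uM; a lower number here means less inhibition, a higher number more inhibition at the concentration tested (going by the name of the read-out):
Compound 1, `CC(/C=C/C1=CCCCC1(C)C)=C\C=C\C(C)=C\COC(=O)c1cc(O)ccc1O`: 25.8%
Compound 2, `CC(/C=C/C1=CCCCC1(C)C)=C\C=C\C(C)=C\COC(=O)c1c(O)cccc1O`: 12.7%

Among the compounds with values here, compound 2 stands lowest of these two numbers in this assay; the only known step is a number 13.1 percentage points lower from compound 1 to compound 2 (beyond the scatter), which moves a hydroxy group on the ring. Compound 3, `COc1cc(O)c(C(=O)OC/C=C(C)/C=C/C=C(C)/C=C/C2=CCCCC2(C)C)c(O)c1`, differs from compound 2 by methoxy in place of hydrogen on an aromatic carbon. Within the data shown here, no measured step adds a methoxy to this ring, so that one step does not bear on the change. Compound 3 is therefore expected to show a number 2.3 percentage points higher from compound 2 to compound 3 (within the scatter), nothing beyond the scatter. For compound 3 the estimate in this assay is 15%, with a range of 3% to 30%.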

Compound 3, a percentage reported as inhibition, at one concentration (the size of the read-out at that concentration, not a potency): 9.5%
Compound 3: the middle estimate sits 5.5 percentage points above what was measured; the measured number falls inside the stated range.
By their numbers in this assay, from the lowest: compounds 3 and 2 (each within the scatter of the next); then compound 1.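

In this assay, methoxy on this aromatic carbon, meta to two hydroxy groups and para to a large group, gives a number 3.2 percentage points lower from compound 2 to compound 3 (within the scatter), so this position accepts the added group without a difference that can be told from scatter. Compared with the other ring pattern, the result is a number 16.3 percentage points lower from compound 1 to compound 3 (beyond the scatter), so compound 3 joins compound 2 in lying beyond the scatter of compound 1. Nothing available explains these results.

Going by these compounds, whether an amine or a carboxylic acid at this carbon would match methoxy remains open, as does the outcome of adding methoxy to the ring of compound 1.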